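The source may report more compounds than this note shows. Statements on the series, on what has been measured and on what is new or still open speak of the compounds shown alone.

Three ureas built on a shared core have been measured in a functional assay on CRL2813 cells (Homo sapiens) for cytotoxicity, read by sulforhodamine B assay, with a stated time of 5 days; a higher number here means a weaker inhibitor, a lower number a stronger inhibitor. Compound 1, with the structure `O=C(Nc1cccc(Br)c1)N[C@H]1CC[C@H](Oc2ccc(F)cc2)CC1`, gives 6200 nM in this assay. Compound 3, `COC(=O)c1ccc(NC(=O)N[C@H]2CC[C@H](Oc3ccc(F)cc3)CC2)cc1`, gives 11600 nM in this assay; the two numbers for compound 1 and compound 3 lie within the usual scatter of each other, so nothing separates them. Compound 2, `O=C(Nc1cccc(C(F)(F)F)c1)N[C@H]1CC[C@H](Oc2cccc(F)c2)CC1`, gives 2400 nM in this assay, a lower number than that of compound 1 and beyond the scatter. Compound 1 thus stands second highest of the three numbers, closest to compound 3 and furthest from compound 2.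

The next compound, compound 4, has the structure `CSc1cccc(NC(=O)N[C@H]2CC[C@H](Oc3ccc(F)cc3)CC2)c1`. It differs from compound 1 in one place: methylsulfanyl in place of bromo on an aromatic carbon. For the measured compounds named here, no pair of measured compounds differs in exactly this way, so the data give no direct guide to the size of such a step. The three measured values span a narrow range, and the exchange of a single substituent on the aromatic ring is expected to move the number little. The step of a 1.0-fold lower number from compound 1 to compound 4 (0.01 log units; within the scatter) is therefore expected to stay within the scatter, with no clear direction. Compound 4 is expected to give about 6000 nM in this assay, with a likely range from 2500 nM to 15000 nM.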

Compound 4, half-maximal inhibitory concentration: 11100 nM
For compound 4 the middle estimate is 1.9-fold (0.27 log units) below the measured one; low and high end bracket the measured number.
By their numbers in this assay, from the lowest: compound 2; then compounds 1, 4 and 3 (each within the scatter of the next).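

In this assay, for the compounds shown here, the exchange of bromo for methylsulfanyl on an aromatic carbon gives a 1.8-fold higher number from compound 1 to compound 4 (0.25 log units; within the scatter), the first step in this set that isolates a single change. With the rest of compound 1 held fixed, this place accepts the swap of bromo, with 1 heavy atom and 0 hydrogen-bond acceptors, for methylsulfanyl, with 2 heavy atoms and 1 hydrogen-bond acceptor, and the two numbers cannot be told apart. No measured property of these compounds bears on this result, so the data offer no account of it.

This single exchange leaves open whether other groups at this place, such as an amine, a carboxylic acid or a longer chain like ethylsulfanyl, would move the number beyond the scatter. Compound 2 differs from compound 1 in more than one place, so the compounds shown do not tell which of its differences goes with its number, or whether the 3-bromophenyl group can be changed to any real effect in this assay.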